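A Benzyl Group on the Saturated Ring of Compound 2

A few compounds are considered here, and "the series" means these few. Any claim that something is new, unique, unknown or untested is made for them only; others in the source may bear on it.

Measured compounds:
- Compound 1, `NS(=O)(=O)Oc1ccc2c(c1)CN(C(=O)c1cccc(N3CCC(N4CCCCC4)CC3)c1)CC2`, gives 0% in an assay on HEK293 cells for inhibition of Steryl-sulfatase (Homo sapiens), tested at 0.1 uM; a lower number here means a weaker effect, a higher number a stronger effect of the compound at the concentration tested.
- Compound 2, `NS(=O)(=O)Oc1ccc2c(c1)CN(C(=O)c1cccc(N3CCCCC3)c1)CC2`, gives 1% in this assay.
- Compound 3, `CCN(Cc1cccc(Br)c1)c1cccc(C(=O)N2CCc3ccc(OS(N)(=O)=O)cc3C2)c1`, gives 20.9% in this assay.

Compound 2 stands second highest of the three numbers in this assay; its nearest neighbour is compound 1, with a number within the scatter of it, and the furthest is compound 3, beyond the scatter. Compound 4, `NS(=O)(=O)Oc1ccc2c(c1)CN(C(=O)c1cccc(N3CCC(Cc4ccccc4)CC3)c1)CC2`, differs from compound 2 in one place: benzyl in place of hydrogen on a saturated ring carbon. The step that bears most directly on this change is a number 1 percentage points higher from compound 1 to compound 2 (within the scatter), which also concerned a group on a saturated ring carbon. The step of a number 19.9 percentage points higher from compound 2 to compound 3 (beyond the scatter) altered a group on an aromatic carbon instead and is less directly comparable. On this basis the expected step of a number 4 percentage points higher from compound 2 to compound 4 (within the scatter) is small, with no clear direction beyond the scatter. Compound 4 is therefore estimated at 5%, within a range from 0% to 20%.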

Compound 4, a percentage reported as inhibition, at one concentration (the size of the read-out at that concentration, not a potency): 1.4%
Estimate against measurement, compound 4: 3.6 percentage points above, within the range that was stated.
By their numbers in this assay, from the lowest: compounds 1, 2 and 4 (each within the scatter of the next); then compound 3.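

In this assay, the step of a number 0.4 percentage points higher from compound 2 to compound 4 (within the scatter) lies within the scatter, so benzyl on this saturated ring carbon, three ring bonds from the ring nitrogen, gives no readable gain over hydrogen. The step of a number 1.4 percentage points higher from compound 1 to compound 4 (within the scatter) is also within the scatter, so this carbon-only aromatic group cannot be told apart from piperidin-1-yl, and the three groups now compared at this position give one flat picture at the concentration tested. No measurement shown here explains this flatness.

On these data alone, it remains open whether a carboxylic acid, a primary amine or a longer chain such as 2-phenylethyl on the same ring carbon would move the number beyond the scatter. Also open, as far as these compounds go, is whether any of these groups would behave differently at a higher concentration.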